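This account rests on a few compounds, and the source may have more. Where it says the series, first, only, none or still open, it means among the compounds named here.

The three measured compounds share one core and differ only in the group on the amide-type nitrogen. Compound 1 `COc1cccc(NC(=O)COc2cc(C)nc3ccc(OC)cc23)c1` carries 3-methoxyphenyl there, and in an ADME assay on HepG2 cells (Homo sapiens) for cytotoxicity, read by trypan blue exclusion, with a stated time of 48 h, in the presence of a further agent that is not named here (a lower number here means that less compound is tolerated, a higher number that more compound is tolerated), compound 1 gives 43000 nM. Compound 2 `COc1ccc2nc(C)cc(OCC(=O)Nc3ccc(Br)cc3)c2c1` carries 4-bromophenyl, and in this assay compound 2 returns only a limit of the assay, > 125000 nM. Compound 3 `COc1ccc2nc(C)cc(OCC(=O)Nc3ccc(C)cc3)c2c1` carries 4-methylphenyl, and in this assay compound 3 likewise returns only a limit, > 149000 nM. Compound 3 thus stands at the top of the measured range, at a limit (the limit of > 149000 nM in this assay, at which 1 of the 3 values shown sits). Compound 2 stands at a neighbouring limit (the limit of > 125000 nM in this assay, at which 1 of the 3 values shown sits).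

Of the measured steps, both aryl replacements moved the number upward: an at least 2.9-fold higher number from compound 1 to compound 2 (0.46 log units; beyond the scatter), and an at least 3.4-fold higher number from compound 1 to compound 3 (0.53 log units; beyond the scatter). Between the two limits, a step that the two limits leave unreadable from compound 2 to compound 3.

Compound 4 `COc1ccc2nc(C)cc(OCC(=O)NCCCc3ccccc3)c2c1` is not yet measured. It differs from compound 3 in one place: 3-phenylpropyl in place of 4-methylphenyl on an amide-type nitrogen. Going by the values given here, the only steps that bear on this change are the two that start from compound 1, and both were upward and ended at a limit. Among the compounds with values here, no measured step shows what a chain in place of an aryl group does on this nitrogen, so the expectation for compound 4 rests on the tolerated range that compound 3 already shows and carries a wide uncertainty. For compound 4 the estimated step is an at least 1.2-fold lower number from compound 3 to compound 4 (0.09 log units; that floor lies within the scatter), within the scatter, and compound 4 is expected to give about 120000 nM, with a likely range from 40000 nM to 200000 nM in this assay.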

Compound 4, half-maximal cytotoxic concentration: > 137000 nM
Compound 4 gave a limit, no number; the forecaster's own chance of this, stated with the estimate: 50%; middle value at least 1.1-fold (0.05 log units) from the limit.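

Compound 4 shows that, in this assay, this amide-type nitrogen tolerates 3-phenylpropyl as well as the aryl groups of compound 2 and compound 3, and it too ends at a limit of the assay: the limit of > 137000 nM in this assay, at which 1 of the 4 values shown sits.

Going by these compounds alone, the one readable step runs in the same direction as the two earlier replacements, an at least 3.1-fold higher number from compound 1 to compound 4 (0.50 log units; beyond the scatter), which leaves compound 1, with 3-methoxyphenyl, as the only one of the four to give a number. The steps that link compound 4 to compound 2 and compound 3 cannot be read, since each joins two limits, so no order among these three compounds can be given.

The compounds shown leave open how far past its limit each of these three lies, and thus whether 3-phenylpropyl differs at all from 4-methylphenyl or 4-bromophenyl. They also leave open what a shorter chain, a chain carrying an amine or a carboxylic acid on this nitrogen would give in this assay, and whether any such group would return a number rather than a limit.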